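The source may report more compounds than this note shows. Statements on the series, on what has been measured and on what is new or still open speak of the compounds shown alone.

Compound 1 `CC(C)=CCOc1cc(Nc2nccs2)ccc1C`: 17000 nM in a functional assay on MT2 cells (Homo sapiens) for cytotoxicity; on this read-out lower numbers stand for higher toxicity in this test and higher numbers for lower toxicity in this test
Compound 2 `CC(C)=CCOc1cc(Nc2nccs2)ccc1C#N`: 500 nM in this assay
Compound 3 `CC(C)=CCOc1cc(Nc2nccc(N)n2)ccc1Cl`: 500 nM in this assay

Compound 3 stands level with compound 2 at the digits given, and the two together sit at the low end of the three numbers in this assay; compound 1 lies a long way higher. For the measured compounds named here, the only single-point step measured so far is a 34-fold lower number from compound 1 to compound 2 (1.53 log units; beyond the scatter), and it concerns the substituent on the aromatic ring, not the heteroaryl group on the ring nitrogen.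

Compound 4 `CC(C)=CCOc1cc(Nc2nccs2)ccc1Cl` is the next compound for this assay. From compound 3 it differs by 1,3-thiazol-2-yl in place of 4-aminopyrimidin-2-yl on a nitrogen on an aromatic ring. Going by the values given here, no measured pair isolates this exchange: compound 2 carries the entering 1,3-thiazol-2-yl and compound 3 the leaving 4-aminopyrimidin-2-yl, but they also differ in the ring substituent, so their equal values show only that the two heteroaryl groups can coexist with the same number. The step from compound 1 to compound 2 does not bear on the change. The expectation for compound 4 is therefore a step of a 1.4-fold higher number from compound 3 to compound 4 (0.15 log units; within the scatter), that is, no change beyond the scatter, with wide uncertainty. Compound 4 is estimated at 700 nM, within 200 nM to 4000 nM.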

Compound 4, half-maximal cytotoxic concentration: 26000 nM
Compound 4: the middle estimate sits 37-fold (1.57 log units) below what was measured, and the stated range ends below it.
By their numbers in this assay, from the lowest: compounds 2 and 3 (each within the scatter of the next); then compounds 1 and 4 (each within the scatter of the next).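

In this assay, the exchange on a nitrogen on an aromatic ring is now isolated with chloro held on the aromatic carbon, and it is large (a 52-fold higher number from compound 3 to compound 4 (1.72 log units; beyond the scatter)): with chloro in place, 1,3-thiazol-2-yl and 4-aminopyrimidin-2-yl are not interchangeable in this test. With 1,3-thiazol-2-yl held, the substituent on the aromatic carbon now has three points: chloro in place of cyano gives a large step (a 52-fold higher number from compound 2 to compound 4 (1.72 log units; beyond the scatter)), while chloro in place of methyl stays within the scatter (a 1.5-fold higher number from compound 1 to compound 4 (0.18 log units; within the scatter)), so among these three compounds only the cyano compound stands apart, at higher toxicity in this test. No measurement available here accounts for either step.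

Going by these compounds, it remains open whether the heteroaryl step depends on the amino group of the 4-aminopyrimidin-2-yl, which a pyrimidin-2-yl carrying no amino group on the same nitrogen would address. Also open, on these data alone, is whether cyano keeps its separation from chloro and methyl with a 4-aminopyrimidin-2-yl on the nitrogen, and where a trifluoromethyl or methoxy group on the same aromatic carbon would fall.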